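Three Anilides at the Assay Limit, a Fourth Untested

The source may hold more compounds than are shown below. What is called first, only, known or untested is meant among the compounds shown, and "the series" means these compounds.

The series shares one core carried on an anilide side chain. Compound 1 `O=C(Cn1c(=O)c(/C=C\c2ccncc2)nc2ccccc21)Nc1ccccc1` bears an unsubstituted phenyl on the amide nitrogen. In a functional assay on cells (Homo sapiens) for inhibition, read by MTT assay, with a stated time of 24 h (on this read-out lower numbers stand for stronger inhibition and higher numbers for weaker inhibition), compound 1 gives only a limit, > 100000 nM. Compound 2 `O=C(Cn1c(=O)c(/C=C\c2ccncc2)nc2ccccc21)Nc1ccc(F)cc1` carries fluoro in place of hydrogen on an aromatic carbon of that phenyl. In this assay compound 2 likewise gives only a limit, > 100000 nM. Compound 3 `O=C(Cn1c(=O)c(/C=C\c2ccncc2)nc2ccccc21)Nc1ccc(Cl)cc1` carries chloro in place of hydrogen on an aromatic carbon. In this assay compound 3 again returns only a limit, > 100000 nM. The three steps, a step that the two limits leave unreadable from compound 1 to compound 2, a step that the two limits leave unreadable from compound 1 to compound 3 and a step that the two limits leave unreadable from compound 2 to compound 3, therefore cannot be sized, because of the limit of > 100000 nM in this assay, at which 3 of the 3 values shown sit. Compound 3 thus stands at the limit of the assay, where the two other values shown also sit.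

Compound 4 `Cc1ccccc1NC(=O)Cn1c(=O)c(/C=C\c2ccncc2)nc2ccccc21` introduces (2-methylphenyl in place of 4-chlorophenyl on an amide-type nitrogen). Among the measured compounds shown here, none of the measured steps gives a readable size or direction, so no step beyond the scatter can be expected in this assay on the evidence at hand; the expected step is a step that the limit leaves unreadable from compound 3 to compound 4. Compound 4 is accordingly expected to sit near 150000 nM, in a range from 40000 nM to 500000 nM, most likely reported again as a limit rather than a number.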

Compound 4, half-maximal inhibitory concentration: 69700 nM
Compound 4: middle estimate off by 2.2-fold (0.33 log units), on the high side; measured number inside the range.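

In this assay, among the compounds shown here, compound 4 is the first of the series to return a number, so 2-methylphenyl on the amide-type nitrogen gives a reading where the unsubstituted phenyl, 4-fluorophenyl and 4-chlorophenyl give only limits. Set against those compounds, the result reads as an at least 1.4-fold lower number from compound 3 to compound 4 (0.15 log units; that floor lies within the scatter), as an at least 1.4-fold lower number from compound 2 to compound 4 (0.15 log units; that floor lies within the scatter) and as an at least 1.4-fold lower number from compound 1 to compound 4 (0.15 log units; that floor lies within the scatter), so the number gives no step that can be called larger than the scatter. Going by these compounds, the true sizes of these steps stay unknown, and the steps among compound 1, compound 2 and compound 3 cannot be read at all, because those three compounds give no number: the limit of > 100000 nM in this assay, at which 3 of the 4 values shown sit.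

The compounds shown leave open whether the reading belongs to the methyl itself or would also appear with an ethyl, a methoxy or an amine on that phenyl ring. They also leave open how a saturated ring such as cyclohexyl, or a longer chain such as benzyl, on the amide-type nitrogen would read in this assay.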